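Extending compound 2 with a tert-butyl ester chain

A few compounds are considered here, and "the series" means these few. Any claim that something is new, unique, unknown or untested is made for them only; others in the source may bear on it.

Three compounds share one core. Compound 1 `CCN1CCc2c(sc(NC=O)c2C(N)=O)C1` carries a formyl group on its core; in a functional assay (strain AB) with Danio rerio as the target, read by microscopy, with a stated time of 1 h (a lower number here means that less compound is needed, a higher number that more compound is needed for the effect), compound 1 reaches only the limit of > 25000 nM. Compound 3 `CCN1CCc2c(sc(NC(=O)Nc3ccc(Cl)cc3)c2C(=O)c2nnco2)C1` also stops at the limit of > 25000 nM in this assay. Among the measured compounds shown here, compound 2 `CN1CCc2c(sc(NC(=O)Nc3ccc(Cl)cc3)c2C(N)=O)C1` gives 4700 nM in this assay, the only measured number among the three, while the other two values sit at the limit of > 25000 nM in this assay, at which 2 of the 3 values shown sit. Compound 4 `CC(C)(C)OC(=O)CCCCCN1CCc2c(sc(NC(=O)Nc3ccc(Cl)cc3)c2C(N)=O)C1` differs from compound 2 by 4-(tert-butoxycarbonyl)butyl in place of hydrogen on a saturated chain carbon bound to an amine nitrogen in a ring. For the measured compounds named here, no measured pair shows a change of this kind, so the size of the step is open; a modest loss is expected, giving a 1.7-fold higher number from compound 2 to compound 4 (0.23 log units; within the scatter). The estimate for compound 4 in this assay is 8000 nM, within a range from 2000 nM to 25000 nM.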

Compound 4, half-maximal effective concentration: 620 nM
For compound 4 the middle estimate is 13-fold (1.11 log units) above the measured one, and the stated range ends above it.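

In this assay the added chain gives a 7.6-fold lower number from compound 2 to compound 4 (0.88 log units; beyond the scatter) and so shows that this place, a saturated chain carbon bound to an amine nitrogen in a ring, accepts a large group without loss. The 4-(tert-butoxycarbonyl)butyl group, with its 11 heavy atoms, lowers the number instead of raising it. Nothing measured here says why the number falls.

On these data alone, whether the gain comes from the chain or from the ester stays open. A carboxylic acid at the chain end, a shorter chain or a longer chain would help to separate the two.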